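Series notes: the step from compound 3 to compound 4

The source may report more compounds than this note shows. Statements on the series, on what has been measured and on what is new or still open speak of the compounds shown alone.

Of the compounds shown here, three have numbers so far. In a functional assay on COLO 205 cells (Homo sapiens) for inhibition, read by sulforhodamine B assay, with a stated time of 48 h, tested at 50 uM (a higher number here means more inhibition of growth at the concentration tested, a lower number less inhibition of growth), compound 1 `COc1ccc(/C=C/C(=O)/C=C/c2ccc(OCc3cn(CCCCCOc4cc(=O)oc5ccccc45)nn3)c(OC)c2)cc1` gives 30%, compound 2 `COc1ccccc1/C=C/C(=O)/C=C/c1ccc(OCc2cn(CCCCOc3cc(=O)oc4ccccc34)nn2)c(OC)c1` gives 47%, and compound 3 `COc1cc(/C=C/C(=O)/C=C/c2cc(OC)c(OC)c(OC)c2)ccc1OCc1cn(CCCOc2cc(=O)oc3ccccc23)nn1` gives 74%. Compound 3 stands highest of the three, with compound 2 nearest and compound 1 furthest, both gaps beyond the scatter. Compound 4 `COc1cccc(/C=C/C(=O)/C=C/c2ccc(OCc3cn(CCCOc4cc(=O)oc5ccccc45)nn3)c(OC)c2)c1` has not been measured. The change from compound 3 to compound 4 is 3-methoxyphenyl in place of 3,4,5-trimethoxyphenyl on a double-bonded chain carbon bound to a double-bonded chain carbon. Going by the values given here, no pair of measured compounds shares exactly this change. Compounds 1 and 2, which carry a methoxyphenyl rather than a trimethoxyphenyl on the double-bonded chain carbon, sit well under compound 3, so a downward step beyond the scatter is expected here. The expected step is a number 29 percentage points lower from compound 3 to compound 4 (beyond the scatter). Compound 4 is estimated to give 45%, within 25% to 65%.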

Compound 4, percent growth inhibition at one concentration: 52%
Compound 4: middle estimate off by 7 percentage points, on the low side; low and high end bracket the measured number.
By their numbers in this assay, from the lowest: compound 1; then compounds 2 and 4 (each within the scatter of the next); then compound 3.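

In this assay, the change from 3,4,5-trimethoxyphenyl to 3-methoxyphenyl gives a number 22 percentage points lower from compound 3 to compound 4 (beyond the scatter). Going by these compounds alone, this is the first comparison that differs in one place, so it ties a real change in growth inhibition to this group on the double-bonded chain carbon, with the rest of the structure held constant. No available evidence explains the step.

From the compounds shown here alone, it remains open whether a dimethoxyphenyl or aminophenyl group at this place would stand nearer compound 3 or compound 4. Going by these compounds, whether the step holds with a longer chain also remains open.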